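This account rests on a few compounds, and the source may have more. Where it says the series, first, only, none or still open, it means among the compounds named here.

Compound 2 `COc1ccc(/C(Cl)=C/C=C(\C#N)C(=O)c2c[nH]c3ccccc23)cc1` in a functional assay for inhibition, read by Griess assay, with a stated time of 150 min, tested at 1 mM (a higher number here means more inhibition at the concentration tested (going by the name of the read-out), a lower number less inhibition), gives 76.9%. Going by the values given here, compound 1 `COc1ccc(/C(Cl)=C/C=C(\C#N)C(=O)c2c[nH]c3ccc(Br)cc23)cc1` carries bromo in place of hydrogen on an aromatic carbon on the shared core and in this assay compound 1 gives 56.2%, so that a number 20.7 percentage points lower from compound 2 to compound 1 (beyond the scatter) marks the only measured instance of this change. The core of compound 3 `COc1ccc(/C(Cl)=C/C=C(\C#N)C(=O)c2c[nH]c3ccccc23)cc1OC` differs from that of compound 2 by methoxy in place of hydrogen on an aromatic carbon; in this assay compound 3 gives 75%, and a number 1.9 percentage points lower from compound 2 to compound 3 (within the scatter) stays within the scatter. Compound 4 `COc1ccc(/C(Cl)=C/C=C(\C#N)C(=O)c2c[nH]c3ccc(Br)cc23)cc1OC` carries bromo in place of hydrogen on an aromatic carbon relative to compound 3, the same change as before, described in the same words of place. The bromo change thus occurs twice in the set, once with a number. Because of a number 20.7 percentage points lower from compound 2 to compound 1 (beyond the scatter) a comparable step of a number 20 percentage points lower from compound 3 to compound 4 (beyond the scatter) is expected in this assay, resting on that one pair alone. Compound 4 is estimated to give 55%, between 42% and 68%, in this assay.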

Compound 4, a percentage reported as inhibition, at one concentration (the size of the read-out at that concentration, not a potency): 57.5%
Beside the measured number, compound 4's estimate is 2.5 percentage points below it; measured number inside the range.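

Bromo in place of hydrogen carries over between the two cores in this assay, with a number 17.5 percentage points lower from compound 3 to compound 4 (beyond the scatter) matching the earlier step: the same change on two cores in this assay, a number 20.7 percentage points lower (beyond the scatter) from compound 2 to compound 1 and a number 17.5 percentage points lower (beyond the scatter) from compound 3 to compound 4, 3.2 percentage points apart, within the scatter of two such steps. Methoxy in place of hydrogen likewise behaves alike on both cores, with a number 1.3 percentage points higher from compound 1 to compound 4 (within the scatter) leaving the number unmoved as before: the same change on two cores in this assay, a number 1.9 percentage points lower (within the scatter) from compound 2 to compound 3 and a number 1.3 percentage points higher (within the scatter) from compound 1 to compound 4, 3.2 percentage points apart, within the scatter of two such steps. This rests on two pairs forming a single square of four compounds, read at one concentration, so it shows additivity of these two changes here and not a rule for other cores or a difference in potency.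

On these data alone, whether an amine or a carboxylic acid in the place of bromo would give a comparable step remains open. So does whether a longer chain in the place of methoxy would leave the number as unmoved.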